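Aryl ketone swap in a pyrazole chalcone-like series

The source may report more compounds than this note shows. Statements on the series, on what has been measured and on what is new or still open speak of the compounds shown alone.

Compound 1 `COc1cc(-c2cc(/C=C/C(=O)c3ccc(Cl)c(Cl)c3)[nH]n2)cc(OC)c1OC` was tested in a functional assay on SF-268 cells (Homo sapiens) for inhibition, read by sulforhodamine B assay, with a stated time of 48 h; on this read-out higher numbers stand for lower toxicity in this test and lower numbers for higher toxicity in this test. For compound 1 the read-out is a limit of the assay, > 100000 nM, not a number. This is where compound 1 stands: at the limit of > 100000 nM in this assay, at which 1 of the 2 values shown sits. Compound 2 `COc1ccc(-c2cc(/C=C/C(=O)c3cc(OC)c(OC)c(OC)c3)[nH]n2)cc1OC` carries methoxy-bearing aryl groups at both ends of the shared core, and in this assay compound 2 gives 9030 nM. Among the measured compounds shown here, compound 1 and compound 2 differ in more than one place, so no single step links them; their two values show only that one sits at the limit and the other inside the measured range.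

Compound 3 `COc1ccc(C(=O)/C=C/c2cc(-c3cc(OC)c(OC)c(OC)c3)n[nH]2)cc1OC` awaits measurement in this assay. It differs from compound 1 by 3,4-dimethoxyphenyl in place of 3,4-dichlorophenyl on a carbonyl carbon. Since compound 1 sits at the limit, any measurable value for compound 3 would be a step downward in the read-out beyond the scatter, toward higher toxicity. Compound 3 is expected to give 30000 nM in this assay, within an estimated range of 5000 nM to 100000 nM. The expected step is an at least 3.3-fold lower number from compound 1 to compound 3 (0.52 log units; beyond the scatter), toward higher toxicity.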

Compound 3, concentration lethal to 50% of the cells: 8590 nM
Compound 3: middle estimate off by 3.5-fold (0.54 log units), on the high side, and the stated range covers the measured number.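

With the rest of the structure held, changing only the aryl group on the carbonyl carbon takes the read-out in this assay from the limit into the measured range: 3,4-dimethoxyphenyl in place of 3,4-dichlorophenyl gives an at least 11-fold lower number from compound 1 to compound 3 (1.06 log units; beyond the scatter), toward higher toxicity. Compound 1 gives > 100000 nM, which is a limit of the assay and not a number. The step is therefore only a bound, and its true size stays unknown because one end of it rests on that limit: the limit of > 100000 nM in this assay, at which 1 of the 3 values shown sits.

A single pair cannot separate the gain of the methoxy groups from the loss of the chlorines. Also open, going by these compounds, are how an unsubstituted phenyl, or a phenyl carrying an amine or a carboxylic acid, would read on this carbonyl carbon, and whether the swap gives a similar step with other groups elsewhere on the shared core.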